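This account rests on a few compounds, and the source may have more. Where it says the series, first, only, none or still open, it means among the compounds named here.

Measured so far:
compound 1 `Cc1c(C(=O)Nc2ccc(C(F)(F)F)cc2)cnn1-c1ccc(F)c(Cl)c1`: 1300 nM
compound 2 `Cc1ccc(NC(=O)c2cnn(-c3ccc(F)cc3)c2C)cc1`: 540 nM
compound 3 `Cc1c(C(=O)Nc2ccc(OC(F)(F)F)cc2)cnn1-c1ccc(F)cc1`: 3400 nM

In a functional assay with Homo sapiens as the target (on this read-out higher numbers stand for weaker inhibition and lower numbers for stronger inhibition), compound 2 has the lowest number of the three and so the strongest inhibition; compound 1 sits a short way above it, and compound 3 further still, as the step of a 6.3-fold higher number from compound 2 to compound 3 (0.80 log units; beyond the scatter) shows. Compound 4 `Cc1cccc(NC(=O)c2cnn(-c3ccc(F)cc3)c2C)c1` differs from compound 2 by 3-methylphenyl in place of 4-methylphenyl on an amide-type nitrogen. Going by the values given here, no measured step rearranges the methyl in this way; the only known step, a 6.3-fold higher number from compound 2 to compound 3 (0.80 log units; beyond the scatter), replaces the methyl with a different group and bears only loosely on this change. Since the two compounds contain the same atoms joined differently, a step of about a 1.5-fold higher number from compound 2 to compound 4 (0.17 log units; within the scatter) is expected for compound 4, not beyond the scatter. The estimate for compound 4 is 800 nM, within 300 nM to 2500 nM.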

Compound 4, half-maximal inhibitory concentration: 5700 nM
Compound 4: the middle estimate sits 7.1-fold (0.85 log units) below what was measured; measured number outside the range, above it.
By their numbers in this assay, from the lowest: compound 2; then compound 1; then compounds 3 and 4 (each within the scatter of the next).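

Moving the methyl alone matters in this assay: with the same atoms in the molecule, 3-methylphenyl in place of 4-methylphenyl on the amide-type nitrogen gives an 11-fold higher number from compound 2 to compound 4 (1.02 log units; beyond the scatter), a large loss of inhibition. The earlier step changed the group itself, whereas this one shows that where the methyl sits on the ring also counts. No measurement at hand explains this drop.

Only the methyl appears here in both placements. From the compounds shown here alone, whether an amine or a carboxylic acid in place of the methyl would respond to the same shift remains open.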